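The source may report more compounds than this note shows. Statements on the series, on what has been measured and on what is new or still open speak of the compounds shown alone.

In an assay on isolated protein for activation of Nicotinamide phosphoribosyltransferase (Homo sapiens) (on this read-out higher numbers stand for an effect only at larger amounts of compound and lower numbers for an effect already at smaller amounts), compound 1 `CNS(=O)(=O)c1ccc(NC(=O)NCc2ccncc2)cc1` gives 3230 nM, the lowest of the two numbers at hand. Compound 3 `CCOC(=O)c1ccc(NC(=S)NCc2ccncc2)cc1` gives 9770 nM, a value that lies beyond the usual scatter from that of compound 1. Compound 2 `CCOC(=O)c1ccc(NC(=O)NCc2ccnnc2)cc1` is reported only as a limit of the assay, > 100000 nM; this is the limit of > 100000 nM in this assay, at which 1 of the 3 values shown sits. Compound 4 `O=C(NCc1ccncc1)Nc1ccc(S(=O)(=O)N2CC3CCC(C2)O3)cc1` has not yet been measured in this assay. It differs from compound 1 in one place: a group of 8 heavy atoms (6 carbon, 1 nitrogen, 1 oxygen; one five-membered non-aromatic ring with 1 hetero atom, one six-membered non-aromatic ring with 2 hetero atoms) in place of a group of 2 heavy atoms (1 carbon, 1 nitrogen; no ring), on a sulfonyl sulfur. Among the measured compounds shown here, no measured pair shares this change, so its effect is open; a step of modest size in either direction, or none beyond the scatter, seems plausible, and the estimate leans slightly toward a lower number. Compound 4 is expected to give about 2000 nM in this assay, with a range from 500 nM to 8000 nM, corresponding to an expected step of a 1.6-fold lower number from compound 1 to compound 4 (0.21 log units; within the scatter).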

Compound 4, half-maximal effective concentration: 279 nM
For compound 4 the middle estimate is 7.2-fold (0.86 log units) above the measured one; measured number below the stated range.
By their numbers in this assay, from the lowest: compound 4; then compound 1; then compound 3. At a limit, above all of these: compound 2.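

In this assay, the sulfonyl sulfur accepts a much larger group with two non-aromatic rings in place of methylamino, giving a 12-fold lower number from compound 1 to compound 4 (1.06 log units; beyond the scatter). The hydrogen-bond donor of the methylamino group is therefore not required at this position for activity in this assay. Nothing measured here bears on the cause of this step. The compounds shown leave open whether a plain piperidine or a morpholine on the sulfonyl sulfur would give a similar number, and thus whether the step depends on both rings or on the ring oxygen.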